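Trifluoromethyl on compound 1: what to expect for compound 3

This account rests on a few compounds, and the source may have more. Where it says the series, first, only, none or still open, it means among the compounds named here.

Compound 1 `C=CCc1cc(-c2ccccc2)ccc1O` gives > 100000 nM (a limit of the assay)
Compound 2 `C=CCc1cc(-c2ccccc2C(F)(F)F)ccc1O` gives 52400 nM (a measured number)

In a functional assay on HepG2 cells (Homo sapiens) for antiproliferative activity, read by MTT assay, with a stated time of 24 h (a higher number here means a weaker inhibitor, a lower number a stronger inhibitor), compound 1 stands at > 100000 nM as a limit of the assay and not a number. The starting point of this step therefore has no exact value.

Compound 3 `C=CCc1cc(-c2ccc(C(F)(F)F)cc2)ccc1O` is compound 1 with one change: trifluoromethyl in place of hydrogen on an aromatic carbon (trifluoromethyl in place of hydrogen on an aromatic carbon, para to a large group). Within the data shown here, one measured step bears on it, the same exchange made on a different carbon to give compound 2. From the compounds shown here alone, that step is an at least 1.9-fold lower number from compound 1 to compound 2 (0.28 log units; that floor lies within the scatter) and only its floor is known, so its true size stays open.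

Taking compound 2 at 52400 nM as the only guide, a modest move towards a lower number is expected in this assay. Compound 3 could also end up at the limit of the assay. The expected step is an at least 1.8-fold lower number from compound 1 to compound 3 (0.25 log units; that floor lies within the scatter) (an estimate measured against a limit). For compound 3 the estimated value is 55000 nM, with an expected range from 25000 nM to 100000 nM (an estimate from one step).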

Compound 3, half-maximal inhibitory concentration: 60300 nM
The estimate for compound 3 lay 1.1-fold (0.04 log units) below the measured number; measured number inside the range.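

With trifluoromethyl in place of hydrogen para to a large group, compound 3 gives a measured number in this assay, and the step is an at least 1.6-fold lower number from compound 1 to compound 3 (0.21 log units; that floor lies within the scatter). Compound 2, which carries the same group on a different carbon, gives 52400 nM, while compound 3 gives 60300 nM, so these two values show that a measured number is reached with the group at either carbon, and they are too close to each other to favour one place over the other. The true size of the step stays unknown, and whether it goes beyond the usual scatter cannot be told, because the value of compound 1 is a limit of the assay and not a number: the limit of > 100000 nM in this assay, at which 1 of the 3 values shown sits.

The compounds shown do not tell whether the gain from compound 1 belongs to trifluoromethyl in particular or would also appear with another group at this carbon, such as an amine, a carboxylic acid or a longer chain. They also leave open what a change elsewhere on the core of compound 1 would do to the number in this assay when trifluoromethyl stays in place.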